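The compounds below may be only part of what the source reports. "The series", "measured", "known", "first", "only" and "open" are said of these compounds alone.

Series in a functional assay on HCT-116 cells (Homo sapiens) for antiproliferative activity, read by MTT assay, with a stated time of 48 h; on this read-out higher numbers stand for weaker inhibition and lower numbers for stronger inhibition:
- compound 1 `COc1ccc(N(C)c2ccnc(Cl)n2)cc1`: 1460 nM
- compound 2 `COc1ccc(N(C)c2ccnc(Cl)n2)cc1Cl`: 1170 nM
- compound 3 `COc1ccc(N(C)c2ccnc(Cl)n2)cc1OCCCCBr`: 1140 nM

Compound 3 stands level with the other two: a 1.3-fold lower number from compound 1 to compound 3 (0.11 log units; within the scatter) and a 1.0-fold lower number from compound 2 to compound 3 (0.01 log units; within the scatter), both within the scatter. Compound 4 `COc1ccc(N(C)c2ccnc(Cl)n2)cc1OCCCCC[Se]C#N` differs from compound 3 by a group of 4 heavy atoms (2 carbon, 1 nitrogen, 1 selenium; no ring) in place of one bromine atom, on a saturated chain carbon, four bonds along the chain from an oxygen on an aromatic ring. The nearest evidence is a 1.2-fold lower number from compound 1 to compound 2 (0.10 log units; within the scatter), alongside the two steps above. All stay within the scatter, but none exchanges the bromine, so they give only a weak guide to this change. A moderately lower number is expected in this assay, as a judgement with a wide margin. The expected step is a 2.3-fold lower number from compound 3 to compound 4 (0.36 log units; beyond the scatter). For compound 4 the estimated value is 500 nM, with an expected range of 80 nM to 1500 nM.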

Compound 4, half-maximal inhibitory concentration: > 10000 nM
Compound 4: only a limit was reported; the forecaster's own chance of this, stated with the estimate: 3%; middle value at least 20-fold (1.30 log units) from the limit.
By their numbers in this assay, from the lowest: compounds 3, 2 and 1 (each within the scatter of the next). At a limit, above all of these: compound 4.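

Among the compounds shown here, exchanging the bromine at the end of the chain is the first change to move the read-out beyond the scatter, as the changes on the aromatic carbon did not: an at least 8.7-fold higher number from compound 3 to compound 4 (0.94 log units; beyond the scatter) in this assay. Compound 4 gives only a limit, > 10000 nM. The step therefore has a floor but no measured size, and it rests on a single value: the limit of > 10000 nM in this assay, at which 1 of the 4 values shown sits.

Whether the selenium, the nitrile or the whole group accounts for the step stays open. A thiocyanate, an amine or a carboxylic acid at the chain end, or a longer chain, could separate these readings.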